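The compounds below may be only part of what the source reports. "The series", "measured", "known", "first", "only" and "open" are said of these compounds alone.

In an ADME assay on L6 cells (Rattus norvegicus) for cytotoxicity (on this read-out lower numbers stand for stronger inhibition and higher numbers for weaker inhibition), compound 3 `O=C(CN1CCC(O)CC1)OC1CC2(N3CCCC3)CC(c3ccccc3)C1C(c1ccccc1)C2` gives 93400 nM and compound 1 `CCN(CC)CC(=O)OC1CC2(N3CCCC3)CC(c3ccccc3)C1C(c1ccccc1)C2` gives 49000 nM, the two lying within the scatter of each other. Compound 2 `O=C(CCN1CCCCC1)OC1CC2(N3CCCC3)CC(c3ccccc3)C1C(c1ccccc1)C2` gives 17800 nM, the lowest number of the three, and the steps to it are a 2.8-fold lower number from compound 1 to compound 2 (0.44 log units; beyond the scatter) and a 5.2-fold higher number from compound 2 to compound 3 (0.72 log units; beyond the scatter). Compound 4 `O=C(CCN1CCC(O)CC1)OC1CC2(N3CCCC3)CC(c3ccccc3)C1C(c1ccccc1)C2` differs from compound 3 by (4-hydroxypiperidin-1-yl)methyl in place of 4-hydroxypiperidin-1-yl on a saturated chain carbon bound to a carbonyl carbon. Going by the values given here, no measured pair isolates this change, since both steps also alter the ring group, so they bear on it only indirectly. Both are modest, and compound 2 holds the lower number, so a modest fall is expected. The expected step is a 2.1-fold lower number from compound 3 to compound 4 (0.32 log units; beyond the scatter). The estimate for compound 4 is 45000 nM, with an expected range of 17000 nM to 100000 nM.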

Compound 4, half-maximal inhibitory concentration: 35600 nM
The estimate for compound 4 lay 1.3-fold (0.10 log units) above the measured number, within the range that was stated.
By their numbers in this assay, from the lowest: compounds 2, 4, 1 and 3 (each within the scatter of the next, the first and the last beyond it).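

In this assay the change from 4-hydroxypiperidin-1-yl to (4-hydroxypiperidin-1-yl)methyl is now measured directly, with the hydroxy group kept in both compounds (a 2.6-fold lower number from compound 3 to compound 4 (0.42 log units; beyond the scatter)). Hydroxy in place of hydrogen on a saturated ring carbon is also isolated for the first time, and this step stays within the scatter (a 2.0-fold higher number from compound 2 to compound 4 (0.30 log units; within the scatter)). (4-Hydroxypiperidin-1-yl)methyl and diethylamino cannot be separated at this position (a 1.4-fold lower number from compound 1 to compound 4 (0.14 log units; within the scatter)).

No available evidence explains these steps. As far as these compounds go, how a longer chain, such as 3-(4-hydroxypiperidin-1-yl)propyl, or a morpholine ring would read at this position remains open.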